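Swapping a para substituent on the benzamide of compound 3

This account rests on a few compounds, and the source may have more. Where it says the series, first, only, none or still open, it means among the compounds named here.

Three compounds share an aminothiazole-type core carrying an acylated amine; one of them, compound 1 `CC(=O)Nc1nc(CCl)c[se]1`, carries a chloromethyl group instead of the isothiocyanatomethyl group found in the others. In a functional assay on L1210 cells (Mus musculus) for antiproliferative activity (a lower number here means a stronger inhibitor, a higher number a weaker inhibitor), compound 1 reaches only the assay limit of > 100000 nM, which is a limit and not a number. Compound 2 `CC(=O)Nc1nc(CN=C=S)cs1`, with an acetyl on the amine, gives 5200 nM in this assay. Compound 3 `COc1ccc(C(=O)Nc2nc(CN=C=S)cs2)cc1`, where a methoxy-substituted benzoyl replaces the acetyl, gives 440 nM, the lowest of the two numbers; the nearest number, that of compound 2, stands higher by a margin beyond the usual scatter.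

Compound 4 `CC(C)(C)c1ccc(C(=O)Nc2nc(CN=C=S)cs2)cc1` differs from compound 3 in one place: tert-butyl in place of methoxy on an aromatic carbon, para to a large group. For the measured compounds named here, no measured pair shows what such a swap does here, so the expectation leans on compound 3 alone. The step from compound 3 to compound 4 is expected to be small, a 1.1-fold higher number from compound 3 to compound 4 (0.06 log units; within the scatter), in no clear direction. Compound 4 is therefore estimated at 500 nM, within a range from 120 nM to 2500 nM.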

Compound 4, half-maximal inhibitory concentration: > 100000 nM
Compound 4 ended at the assay's limit; the forecaster's own chance of this, stated with the estimate: 5%; middle value at least 200-fold (2.30 log units) from the limit.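

At this place on the aromatic ring, para to a large group, the choice of substituent is far from a minor detail: tert-butyl in place of methoxy gives an at least 220-fold higher number from compound 3 to compound 4 (2.35 log units; beyond the scatter) in this assay even though the isothiocyanatomethyl group stays the same. For the compounds shown here, no earlier pair tested a swap at this place, so this is the first sign that activity can depend heavily on the group carried here. The reading for compound 4 is a limit and not a number: the limit of > 100000 nM in this assay, at which 2 of the 4 values shown sit.

Only methoxy and tert-butyl are shown at this place, so it stays open how a methyl group, a chlorine atom or an amine would behave there in this assay. As far as these compounds go, it also stays open whether the drop comes with the loss of methoxy or with the arrival of tert-butyl.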